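A few compounds are considered here, and "the series" means these few. Any claim that something is new, unique, unknown or untested is made for them only; others in the source may bear on it.

Of the compounds shown here, two sharing one core have been measured in a functional assay on HEK293 cells for agonist activity at growth hormone secretagogue receptor type 1 (Homo sapiens), read by HTRF and inositol phosphate accumulation, with a stated time of 90 min, in the presence of a further agent that is not named here; a higher number here means a larger maximal response, a lower number a smaller maximal response. Compound 1 `CN(C(=O)c1cc(-c2ccccc2Cl)on1)[C@H]1CN(S(=O)(=O)c2ccccc2)C[C@@H]1C(=O)N[C@H]1CCCNC1` gives 103%. Compound 2 `CN(C(=O)[C@H]1CN(S(=O)(=O)c2ccccc2)C[C@@H]1NC(=O)c1cc(-c2ccccc2Cl)on1)[C@H]1CCCNC1` gives 88%, the lower of the two numbers, with compound 1 standing higher by a gap beyond the usual scatter. Compound 3 `CN(C(=O)[C@H]1CN(S(=O)(=O)c2ccccc2)C[C@@H]1N(C)C(=O)c1cc(-c2ccccc2Cl)on1)[C@H]1CCCNC1` differs from compound 2 in one place: methyl in place of hydrogen on an amide-type nitrogen. Going by the values given here, no measured pair shows this change, so its effect is unknown, and a small step downward or none beyond the scatter is expected. Compound 3 is estimated at 82%, in a range from 60% to 100%. The expected step is a number 6 percentage points lower from compound 2 to compound 3 (within the scatter).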

Compound 3, largest response reached (Emax), in percent of the reference or control that the assay uses: 95%
For compound 3 the middle estimate is 13 percentage points below the measured one; the measured number falls inside the stated range.
By their numbers in this assay, from the lowest: compounds 2, 3 and 1 (each within the scatter of the next, the first and the last beyond it).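

In this assay, methyl in place of hydrogen on an amide-type nitrogen gives a number 7 percentage points higher from compound 2 to compound 3 (within the scatter), and the same change on the second amide-type nitrogen gives a number 8 percentage points lower from compound 1 to compound 3 (within the scatter). Neither step lies beyond the scatter, so the maximal response survives the loss of either amide hydrogen, and compound 3 carries methyl on both nitrogens. Nothing available explains this result. From the compounds shown here alone, whether ethyl or a longer chain on either nitrogen would leave the response equally intact remains open.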